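The source may report more compounds than this note shows. Statements on the series, on what has been measured and on what is new or still open speak of the compounds shown alone.

Three related compounds have been tested in a functional assay on A549 cells (Homo sapiens) for antiproliferative activity, read by MTT assay, with a stated time of 24 h; a higher number here means a weaker inhibitor, a lower number a stronger inhibitor. Compound 1 `O=C(NNc1ccccc1F)c1ccc(NS(=O)(=O)c2cnc(O)nc2O)cc1` carries a 2-fluorophenyl group on an amine nitrogen whose other neighbour is an amide-type nitrogen, and in this assay compound 1 gives 11700 nM. Compound 2 `O=C(NNc1ccc(F)cc1)c1ccc(NS(=O)(=O)c2cnc(O)nc2O)cc1` differs from compound 1 by one change, (4-fluorophenyl in place of 2-fluorophenyl on an amine nitrogen). For compound 2 this assay reports only a limit, > 20000 nM. The measured step is an at least 1.7-fold higher number from compound 1 to compound 2 (0.23 log units; that floor lies within the scatter); its full size cannot be told, because the limit of > 20000 nM in this assay, at which 1 of the 3 values shown sits, caps what can be seen. Compound 3 `O=C(NNc1ccccc1F)c1ccccc1NS(=O)(=O)c1cnc(O)nc1O` keeps the 2-fluorophenyl group on the same kind of amine nitrogen but is built on a different core; the difference between the two cores is not broken down here. In this assay compound 3 gives 9610 nM, which sits within the scatter of compound 1.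

Compound 4 `O=C(NNc1ccc(F)cc1)c1ccccc1NS(=O)(=O)c1cnc(O)nc1O` has not yet been measured. It stands to compound 3 as compound 2 stands to compound 1: 4-fluorophenyl in place of 2-fluorophenyl on an amine nitrogen. The place of the change reads the same word for word in both pairs, so this is the same change made on a second core. The expectation for compound 4 rests on compound 1 and compound 2, whose step in this assay was an at least 1.7-fold higher number from compound 1 to compound 2 (0.23 log units; that floor lies within the scatter). Compound 4 is therefore expected to give about 18000 nM in this assay, estimated to lie between 9000 nM and 40000 nM. That estimate means an expected step of a 1.9-fold higher number from compound 3 to compound 4 (0.27 log units; within the scatter), with a real chance that this assay again reports only a limit.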

Compound 4, half-maximal inhibitory concentration: > 20000 nM
Compound 4 ended at the assay's limit; the forecaster's own chance of this, stated with the estimate: 45%; at least 1.1-fold (0.04 log units) between middle value and limit.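

In this assay, putting 4-fluorophenyl in place of 2-fluorophenyl on the amine nitrogen of the second core gives an at least 2.0-fold higher number from compound 3 to compound 4 (0.31 log units; beyond the scatter). Among the compounds shown here, both cores therefore move toward a higher number, meaning a weaker inhibitor, with the same change, although only the step on the second core is beyond the scatter, and the two steps cannot be compared in size: the same change on two cores in this assay, an at least 1.7-fold higher number (0.23 log units; that floor lies within the scatter) from compound 1 to compound 2 and an at least 2.0-fold higher number (0.31 log units; beyond the scatter) from compound 3 to compound 4; the limit leaves it open whether they differ. This shows that the change carries over in direction in these two pairs, but it does not show that it costs the same on both cores or give the full size of either step, since each compound with the 4-fluorophenyl group ends at a limit, which is not a number: the limit of > 20000 nM in this assay, at which 2 of the 4 values shown sit.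

The compounds shown do not tell how weak compound 2 and compound 4 really are, so any difference between the two cores in their response to this change stays open. They also leave open how the two fluorophenyl groups compare with a plain phenyl ring on that nitrogen, or with a phenyl ring carrying a chlorine, a methoxy group or an amine in place of the fluorine.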